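A few compounds are considered here, and "the series" means these few. Any claim that something is new, unique, unknown or untested is made for them only; others in the source may bear on it.

Working notes on the series. The shared core carries a cinnamamide-type linker joined to a substituted aryl ring; compound 1 `COCCOc1ccc(/C=C/C(=O)Nc2nc(-c3c(C)cc(C)cc3C)cs2)cc1`, compound 2 `COc1cc(/C=C/C(=O)Nc2nc(-c3c(C)cc(C)cc3C)cs2)cc(OC)c1OC` and compound 3 `Cc1ccc(/C=C/C(=O)Nc2nc(-c3c(C)cc(C)cc3C)cs2)cc1` differ only on that aryl ring. In a functional assay on K562 cells (Homo sapiens) for inhibition, read by MTT assay, with a stated time of 96 h (on this read-out higher numbers stand for weaker inhibition and lower numbers for stronger inhibition), compound 1 gives 1490 nM, compound 2 gives 11800 nM and compound 3 gives 7880 nM. Compound 3 thus stands second highest of the three numbers; its gap to compound 2 lies within the scatter, while the step of a 5.3-fold higher number from compound 1 to compound 3 (0.72 log units; beyond the scatter) lies beyond it.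

Compound 4 `Cc1cc(C)c(-c2csc(NC(=O)/C=C/c3ccc([N+](=O)[O-])cc3)n2)c(C)c1` is the next member, not yet measured in this assay. Its change from compound 3 is nitro in place of methyl on an aromatic carbon, on an aromatic carbon of the six-membered carbon-only ring, para to a large group. Within the data shown here, no measured step involves a nitro group, so only the step from compound 1 to compound 3 bears on this position at all, and it concerns a different pair of groups. Compound 4 is therefore expected to stay near compound 3, with the step of a 1.3-fold lower number from compound 3 to compound 4 (0.12 log units; within the scatter) estimated as no clear movement beyond the scatter. The estimate for compound 4 in this assay is 6000 nM, with a range from 1500 nM to 25000 nM.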

Compound 4, half-maximal inhibitory concentration: 32200 nM
Compound 4: middle estimate off by 5.4-fold (0.73 log units), on the low side; the measured number lies above the stated range.
By their numbers in this assay, from the lowest: compound 1; then compounds 3 and 2 (each within the scatter of the next); then compound 4.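

The position para to a large group is not indifferent to this change: in this assay nitro in place of methyl gives a 4.1-fold higher number from compound 3 to compound 4 (0.61 log units; beyond the scatter) and so moves the number beyond the scatter. Nitro in place of 2-methoxyethoxy gives a 22-fold higher number from compound 1 to compound 4 (1.33 log units; beyond the scatter) and is the largest single-place step so far, so the three groups at this carbon now rank from 2-methoxyethoxy through methyl to nitro, from lowest number to highest. Nothing at hand accounts for this order.

As far as these compounds go, how an amine, a carboxylic acid or a longer chain on this carbon would rank against these three groups stays open. From the compounds shown here alone, whether nitro on another carbon of the ring would also raise the number stays open too.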